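Moving the branch point along the alkoxy chain

This account rests on a few compounds, and the source may have more. Where it says the series, first, only, none or still open, it means among the compounds named here.

Measured so far:
compound 1 `CCCCCCCOc1ccc(C(CC(=O)O)c2ccccc2)cc1`, 4.26 uM
compound 2 `CC(C)CCOc1ccc(C(CC(=O)O)c2ccccc2)cc1`, 1.86 uM

Both were tested in a functional assay on HEK293 cells for agonist activity at Free fatty acid receptor 1 (Homo sapiens), read by calcium flux; on this read-out higher numbers stand for an effect only at larger amounts of compound and lower numbers for an effect already at smaller amounts. Going by the values given here, compound 2 gives the lowest of the two numbers; the nearest is compound 1, and the only measured step is a 2.3-fold lower number from compound 1 to compound 2 (0.36 log units; beyond the scatter). Compound 3 `CCC(C)COc1ccc(C(CC(=O)O)c2ccccc2)cc1` keeps the same atoms, joined differently: sec-butyl in place of isobutyl on a saturated chain carbon bound to an oxygen on an aromatic ring. Among the compounds with values here, no measured step moves a branch along a chain, so the single step from compound 1 to compound 2 bears on it only loosely. For compound 3 a step of about a 1.1-fold higher number from compound 2 to compound 3 (0.03 log units; within the scatter) is expected, within the scatter. The estimate for compound 3 is 2 uM, ranging from 1 uM to 4 uM.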

Compound 3, concentration for half-maximal effect: 0.3 uM
Compound 3: middle estimate off by 6.7-fold (0.82 log units), on the high side; measured number outside the range, below it.
By their numbers in this assay, from the lowest: compound 3; then compound 2; then compound 1.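

Swapping isopentyloxy for 2-methylbutoxy keeps every atom and only rejoins them, yet it gives a 6.2-fold lower number from compound 2 to compound 3 (0.79 log units; beyond the scatter), so at this position the arrangement of the chain atoms matters, not only their number. Compared with the straight chain of compound 1, the change amounts to a 14-fold lower number from compound 1 to compound 3 (1.15 log units; beyond the scatter). No available evidence explains why this rearrangement lowers the number.

The compounds shown leave open whether a branch further along a longer chain, as in 2-methylpentyloxy, keeps the low number. They also leave open what a ring such as cyclopropylmethoxy would do here.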